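Varying the acid-bearing group on the shared core

A few compounds are considered here, and "the series" means these few. Any claim that something is new, unique, unknown or untested is made for them only; others in the source may bear on it.

Measured compounds:
compound 1 `C[C@@H](C(=O)O)c1nn(Cc2cn3cc(OCC4CC4)c(Cl)cc3n2)c2ccccc2c1=O` — in a functional assay on HFL1 cells for antagonist activity at sphingosine 1-phosphate receptor 2 (Homo sapiens), read by ELISA, with a stated time of 24 h, in the presence of a further agent that is not named here (on this read-out lower numbers stand for stronger inhibition and higher numbers for weaker inhibition), compound 1 gives 3180 nM
compound 2 `O=C(O)C1(c2nn(Cc3cn4cc(OCC5CC5)c(Cl)cc4n3)c3ccccc3c2=O)CC1` — in this assay compound 2 gives 304 nM

For the measured compounds named here, compound 2 stands at the lower of the two numbers; the only measured step, a 10-fold lower number from compound 1 to compound 2 (1.02 log units; beyond the scatter), separates it from compound 1, which gives the higher number. Compound 3 `CC(C)(C(=O)O)c1nn(Cc2cn3cc(OCC4CC4)c(Cl)cc3n2)c2ccccc2c1=O` is the next member: 1-carboxy-1-methylethyl in place of 1-carboxycyclopropyl on an aromatic carbon. Going by the values given here, the one step that bears on it is the step from compound 1 to compound 2, which was large and went in favour of the ring. Among the compounds with values here, compound 3 returns to an open chain, as in compound 1, yet keeps the heavy-atom count of compound 2, so the data give no direct precedent. The open chain of compound 1 sat well above compound 2; a return toward that region, though probably not all the way, is the working assumption. In this assay compound 3 is therefore expected to give 900 nM, with a range of 250 nM to 3000 nM. The estimated step is a 3.0-fold higher number from compound 2 to compound 3 (0.47 log units; beyond the scatter), a weakening that is expected to fall short of the full gap back to compound 1.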

Compound 3, half-maximal inhibitory concentration: 361 nM
Compound 3: the middle estimate sits 2.5-fold (0.40 log units) above what was measured; the range from low to high includes it.
By their numbers in this assay, from the lowest: compounds 2 and 3 (each within the scatter of the next); then compound 1.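

In this assay, there is a 1.2-fold higher number from compound 2 to compound 3 (0.07 log units; within the scatter), so 1-carboxycyclopropyl and 1-carboxy-1-methylethyl, which have the same heavy-atom count, cannot be told apart on this aromatic carbon. The earlier gain therefore does not depend on the three-membered ring: the open-chain group also gives an 8.8-fold lower number from compound 1 to compound 3 (0.94 log units; beyond the scatter), in line with a 10-fold lower number from compound 1 to compound 2 (1.02 log units; beyond the scatter), and among these three compounds the two lower numbers belong to the groups with two carbon substituents on the carbon bearing the acid, while compound 1, with a single methyl there, gives the higher number, with no listed compound going against this. No supporting measurement bears on why this change has so much weight at this position.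

The compounds shown leave open how far this tolerance extends, for example to 1-carboxycyclobutyl or to a 1-carboxy-1-ethylpropyl group on the same aromatic carbon. They also leave open whether a primary amide or a tetrazole could stand in place of the carboxylic acid while the number stays near those of compound 2 and compound 3.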